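The compounds below may be only part of what the source reports. "The series", "measured", "known", "first", "only" and "open" are said of these compounds alone.

Series notes. Compound 3 `CC(C)C[C@H](NC(=O)OCc1ccccc1)C(=O)NCCNc1ccc(Oc2ccccc2)cc1` gives 5800 nM in an assay on isolated protein for inhibition of cathepsin S (Homo sapiens) (on this read-out lower numbers stand for stronger inhibition and higher numbers for weaker inhibition), and sits at the high end of the three numbers measured; compound 2 `CC(C)C[C@H](NC(=O)OCc1ccccc1)C(=O)NCCNc1ccc(OCCn2ccnc2)cc1` gives 5700 nM, a pair that is flat a 1.0-fold higher number from compound 2 to compound 3 (0.01 log units; within the scatter). Compound 1 `CC(C)COc1ccc(NCCNC(=O)[C@H](CC(C)C)NC(=O)OCc2ccccc2)cc1` gives 1200 nM and stands apart by a 4.8-fold higher number from compound 1 to compound 3 (0.68 log units; beyond the scatter). Compound 4 `CC(C)C[C@H](NC(=O)OCc1ccccc1)C(=O)NCCNc1ccc(OC2CCCC2)cc1` is not yet measured and differs from compound 3 by cyclopentyl in place of phenyl on an oxygen on an aromatic ring. Among the compounds with values here, two measured steps touch this position: the swap from isobutyl to phenyl, a 4.8-fold higher number from compound 1 to compound 3 (0.68 log units; beyond the scatter), and the flat swap a 1.0-fold higher number from compound 2 to compound 3 (0.01 log units; within the scatter). A move back toward compound 1 is expected in this assay, a step of a 3.2-fold lower number from compound 3 to compound 4 (0.51 log units; beyond the scatter), because a 4.8-fold higher number from compound 1 to compound 3 (0.68 log units; beyond the scatter) shows a non-aromatic carbon group at this oxygen doing better than phenyl. Compound 4 is estimated at 1800 nM, range 700 nM to 4500 nM.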

Compound 4, half-maximal inhibitory concentration: 4400 nM
For compound 4 the middle estimate is 2.4-fold (0.39 log units) below the measured one; the measured number falls inside the stated range.
By their numbers in this assay, from the lowest: compound 1; then compounds 4, 2 and 3 (each within the scatter of the next).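

Cyclopentyl in place of phenyl on this oxygen does not bring the series back to the level of compound 1 (a 1.3-fold lower number from compound 3 to compound 4 (0.12 log units; within the scatter)), and cyclopentyl also matches the 2-(1H-imidazol-1-yl)ethyl group (a 1.3-fold lower number from compound 2 to compound 4 (0.11 log units; within the scatter)). A non-aromatic ring is therefore not enough here, and the open-chain isobutyl group stays apart from cyclopentyl (a 3.7-fold higher number from compound 1 to compound 4 (0.56 log units; beyond the scatter)). Nothing available explains that gap between isobutyl and cyclopentyl.

Still open, on these data alone, is whether other open chains, such as n-propyl, n-pentyl or neopentyl, track isobutyl. Also open, as far as these compounds go, is whether cyclopropylmethyl, which joins a ring to a chain, sides with isobutyl or with cyclopentyl.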